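Compound 1 to compound 3: sulfanyl for benzylamino

The source may report more compounds than this note shows. Statements on the series, on what has been measured and on what is new or still open speak of the compounds shown alone.

Among the compounds with values here, compound 1 `Nc1cc(N)c2nc(-c3ccccc3)c(NCc3ccc(F)cc3)nc2c1` is the reference point of the two numbers measured so far. In a functional assay on TK-10 cells (Homo sapiens) for inhibition, read by sulforhodamine B assay, with a stated time of 48 h (on this read-out lower numbers stand for stronger inhibition of growth and higher numbers for weaker inhibition of growth), compound 1 gives 5890 nM, the lowest of the pair; compound 2 `COc1ccc(CNc2nc3cc(N)cc(N)c3nc2-c2ccccc2)cc1` gives 28200 nM in this assay. Within the data shown here, the one measured step, a 4.8-fold higher number from compound 1 to compound 2 (0.68 log units; beyond the scatter), concerns the fluoro group alone. Compound 3 `Nc1cc(N)c2nc(-c3ccccc3)c(Sc3ccc(F)cc3)nc2c1` differs from compound 1 at another place: (4-fluorophenyl)sulfanyl in place of (4-fluorobenzyl)amino on an aromatic carbon. Among the measured compounds shown here, no measured step bears on this change; the step from compound 1 to compound 2 alters only the fluoro group, which compound 3 keeps, and says nothing about the group that joins the fluorinated ring to the shared core. The expectation for compound 3 therefore rests on compound 1 alone and carries a wide range. Compound 3 is estimated at 10000 nM in this assay, with a range from 3000 nM to 40000 nM. That estimate means an expected step of a 1.7-fold higher number from compound 1 to compound 3 (0.23 log units; within the scatter), modest and not clearly beyond the scatter.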

Compound 3, concentration for 50% growth inhibition: < 100000 nM
Compound 3: a limit, no number; the forecaster's own chance of this, stated with the estimate: 10%; the middle value does not contradict the limit.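

In this assay compound 3 gives < 100000 nM, a limit and not a number. Within the data shown here, no step from compound 1 to compound 3 can be read from it. The compounds shown leave open how far, and in which direction, (4-fluorophenyl)sulfanyl in place of (4-fluorobenzyl)amino shifts growth inhibition on the shared core.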